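This account rests on a few compounds, and the source may have more. Where it says the series, first, only, none or still open, it means among the compounds named here.

In a functional assay on the whole organism (strain albino) for inhibition, with Rattus norvegicus as the target, read by paw edema, with stated times of 30 min and 1 h, at a dose of 100 mg/kg by the oral route (on this read-out lower numbers stand for less inhibition and higher numbers for more inhibition at the one dose given (going by the name of the read-out)), compound 3 `O=C(CO[N+](=O)[O-])Nc1ccc(C(=O)/C=C/c2ccc(Cl)cc2)cc1` gives 42%. Among the measured compounds shown here, on the three numbers measured so far it stands second highest. Its nearest neighbour is compound 2 `O=C(CBr)Nc1ccc(C(=O)/C=C/c2ccc(Cl)cc2)cc1`, which in this assay gives 44%, a number within the usual scatter of compound 3. Furthest from it is compound 1 `Nc1ccc(C(=O)/C=C/c2ccco2)cc1`, which gives 33%, and that gap too lies within the scatter, so the three measured compounds cannot be ordered.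

For the measured compounds named here, the only step measured between compounds that differ in one place is a number 2 percentage points lower from compound 2 to compound 3 (within the scatter), a change of nitrooxy in place of bromo on a saturated chain carbon bound to a carbonyl carbon. It does not concern the change now in question.

Compound 4 `O=C(CO[N+](=O)[O-])Nc1ccc(C(=O)/C=C/c2ccco2)cc1` differs from compound 3 by furan-2-yl in place of 4-chlorophenyl on a double-bonded chain carbon bound to a double-bonded chain carbon. Going by the values given here, no measured step bears on this change. Among the compounds with values here, compound 1 also carries the furan-2-yl, but it differs from compound 3 in more than one place, so what its value shows is only that compound 1 and compound 3 lie within the scatter of each other. The step expected from compound 3 to compound 4 is therefore a number 4 percentage points lower from compound 3 to compound 4 (within the scatter), none beyond the scatter. Compound 4 is estimated to give 38% in this assay, with a range from 27% to 49%.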

Compound 4, a percentage reported as inhibition, in the whole organism at one dose (the size of the read-out at that dose, not a potency): 34%
Compound 4: middle estimate off by 4 percentage points, on the high side, within the range that was stated.
By their numbers in this assay, from the lowest: compounds 1, 4, 3 and 2 (each within the scatter of the next, the first and the last beyond it).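

In this assay, the exchange of 4-chlorophenyl for furan-2-yl on a double-bonded chain carbon bound to a double-bonded chain carbon now has a measured step of its own, a number 8 percentage points lower from compound 3 to compound 4 (within the scatter); with the nitrooxy-bearing side chain held constant, the two groups cannot be told apart at this position. Among the compounds shown here, the second new step, a number 1 percentage points higher from compound 1 to compound 4 (within the scatter), gives the first direct reading of ((nitrooxy)methyl)carbonyl in place of hydrogen on a nitrogen on an aromatic ring, and with furan-2-yl held constant, this change also cannot be told apart from the scatter. Nothing at hand gives a measured property of these groups that would bear on either step.

Going by these compounds, it remains open whether the ((nitrooxy)methyl)carbonyl change would read the same with 4-chlorophenyl in place of furan-2-yl, and whether bromo and nitrooxy would stay indistinguishable with furan-2-yl present. Also open, on these data alone, is how a group of another kind at the double-bonded chain carbon, such as a phenyl ring carrying a carboxylic acid or a dimethylamino group, would read in this assay.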